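The source may hold more compounds than are shown below. What is called first, only, known or untested is meant among the compounds shown, and "the series" means these compounds.

The shared core is that of compound 1 `O=C(Nc1ccccc1C(F)(F)F)C1CCc2ccccc2N1`, which in a functional assay on HCT-15 cells (Homo sapiens) for cytotoxicity, read by sulforhodamine B assay, with a stated time of 72 h (a lower number here means a stronger inhibitor of growth, a higher number a weaker inhibitor of growth), gives 40400 nM. Of the two compounds with a number in this assay, compound 1 stands as the higher; the nearest is compound 2 `O=C(Nc1ccccc1C(F)(F)F)C1CCc2ccccc2N1C(=O)c1ccc(Cl)cc1`, which in this assay gives 839 nM, so the step of a 48-fold lower number from compound 1 to compound 2 (1.68 log units; beyond the scatter) is large. Compound 3 `CC(=O)N1c2ccccc2CCC1C(=O)Nc1ccccc1C(F)(F)F` gives in this assay only a limit, > 80000 nM, as set out in the limit of > 80000 nM in this assay, at which 1 of the 3 values shown sits. The step of an at least 1.9-fold higher number from compound 1 to compound 3 (0.29 log units; that floor lies within the scatter) and the step of an at least 95-fold higher number from compound 2 to compound 3 (1.97 log units; beyond the scatter) both concern the group on the ring nitrogen. Compound 4 `O=C(Nc1ccccc1)C1CCc2ccccc2N1` differs from compound 1 in another place: hydrogen in place of trifluoromethyl on an aromatic carbon. Among the measured compounds shown here, none of the measured steps touches the aromatic ring that carries the trifluoromethyl, so none speaks directly to this change; they show only that the acyl group on the ring nitrogen moves the number a long way, and that compound 1, with hydrogen on that nitrogen, sits at the weak end. With no comparison for the trifluoromethyl itself, the expected step of a 1.5-fold higher number from compound 1 to compound 4 (0.17 log units; within the scatter) is taken as small, with a wide uncertainty that reaches up to the limit of this assay. Compound 4 is therefore expected to give about 60000 nM, within a range from 15000 nM to 160000 nM.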

Compound 4, concentration for 50% growth inhibition: 109000 nM
Beside the measured number, compound 4's estimate is 1.8-fold (0.26 log units) below it, and the stated range covers the measured number.
By their numbers in this assay, from the lowest: compound 2; then compound 1; then compound 4.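

Among the compounds shown here, compound 4 gives the first measured change on the aromatic ring that carries the trifluoromethyl, as all the earlier steps concerned the group on the ring nitrogen. In this assay, the change gives a 2.7-fold higher number from compound 1 to compound 4 (0.43 log units; beyond the scatter), so this place does register on growth inhibition, although the step is far smaller than the large 48-fold lower number from compound 1 to compound 2 (1.68 log units; beyond the scatter) seen on acylating the ring nitrogen with the (4-chlorophenyl)carbonyl group. Nothing among the data shown accounts for the step at the trifluoromethyl place.

As far as these compounds go, the comparison rests on a single pair with hydrogen on the ring nitrogen, so it remains open whether removing the trifluoromethyl would move the number by a similar amount in compound 2, where the (4-chlorophenyl)carbonyl group is present. From the compounds shown here alone, it also remains open how a methyl, a chlorine, a methoxy or a nitrile on the same aromatic carbon would compare with trifluoromethyl and with hydrogen.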